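This account rests on a few compounds, and the source may have more. Where it says the series, first, only, none or still open, it means among the compounds named here.

Measured so far:
- compound 1, `C[C@]1(O)CC(=O)OC(CSc2nc(-c3ccccc3)c(-c3ccccc3)[nH]2)C1`: 140 nM
- compound 2, `C[C@@]1(O)CC(=O)OC(CSc2nc(-c3cccc(Cl)c3)c(-c3cccc(Cl)c3)[nH]2)C1`: 110 nM
- compound 3, `COc1cccc(-c2nc(SCC3C[C@](C)(O)CC(=O)O3)[nH]c2-c2cccc(OC)c2)c1`: 570 nM

All three share the same core and were tested in an assay on microsomes from liver for inhibition of sterol O-acyltransferase 1 (Rattus norvegicus); on this read-out lower numbers stand for stronger inhibition and higher numbers for weaker inhibition. Among these three numbers compound 1 stands second highest. Its nearest neighbour is compound 2, whose number lies within the usual scatter of compound 1, so the two cannot be told apart. Its furthest neighbour is compound 3, which gives a clearly higher number, beyond the scatter, and so is the weaker inhibitor of the pair.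

Compound 4, `c1ccc(-c2nc(SCC3CCCCC3)[nH]c2-c2ccccc2)cc1`, has not yet been measured. It differs from compound 1 in one place: a group of 6 heavy atoms (6 carbon; one six-membered non-aromatic ring of carbon only) in place of a group of 9 heavy atoms (6 carbon, 3 oxygen; one six-membered non-aromatic ring with 1 hetero atom), on a saturated chain carbon bound to a sulfur. The group that leaves carries the only stereocentre, the hydrogen-bond donor and the three acceptors of that part of compound 1; the cyclohexyl that enters carries none of these.

Among the compounds with values here, no measured pair shows this kind of exchange, so any expectation rests on compound 1 alone, with its value 140 nM. In this assay the step from compound 1 to compound 4 is expected to be a moderate rise, a 3.2-fold higher number from compound 1 to compound 4 (0.51 log units; beyond the scatter), that is, weaker inhibition. Compound 4 is therefore estimated at 450 nM, with a likely range from 130 nM to 1600 nM.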

Compound 4, half-maximal inhibitory concentration: 100 nM
For compound 4 the middle estimate is 4.5-fold (0.65 log units) above the measured one; measured number below the stated range.
By their numbers in this assay, from the lowest: compounds 4, 2 and 1 (each within the scatter of the next); then compound 3.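

In this assay, putting cyclohexyl in place of the oxygen-containing six-membered ring on the saturated chain carbon bound to a sulfur gives a 1.4-fold lower number from compound 1 to compound 4 (0.15 log units; within the scatter), so the two compounds cannot be told apart. At this place, then, the hydrogen-bond donor, the hydrogen-bond acceptors and the stereocentre of the departing group are not needed to reach a number of this size, since compound 4 has none of them there. Nothing available here explains why the exchange leaves the number within the scatter.

The compounds shown leave open how an amine, a carboxylic acid or an open hexyl chain at this place would compare with cyclohexyl. They also leave open whether cyclohexyl would give a similar result alongside the chloro groups of compound 2 or the methoxy groups of compound 3.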